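Swapping chloro for methoxy on a fluorinated amidine

This account rests on a few compounds, and the source may have more. Where it says the series, first, only, none or still open, it means among the compounds named here.

Of the compounds shown here, three built on a shared core have been tested in a functional assay on KM12 cells (Homo sapiens) for inhibition, read by sulforhodamine B assay, with a stated time of 48 h; a higher number here means a weaker inhibitor of growth, a lower number a stronger inhibitor of growth. Compound 3 `N=C(N)c1ccc(-c2ccc(-c3ccc(Cl)cc3)s2)cc1` gives 196 nM. Compound 1 `COc1ccc(-c2ccc(-c3ccc(C(=N)N)cc3)s2)cc1` gives 339 nM, and the change from compound 3 to compound 1 is methoxy in place of chloro on an aromatic carbon, which gave a 1.7-fold higher number from compound 3 to compound 1 (0.24 log units; within the scatter). Compound 2 `N=C(N)c1ccc(-c2ccc(-c3ccc(Cl)cc3)s2)cc1F` gives 226 nM; its core differs from that of compound 3 by fluoro in place of hydrogen on an aromatic carbon, and the step from compound 2 to compound 3 was a 1.2-fold lower number from compound 2 to compound 3 (0.06 log units; within the scatter).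

Compound 4 `COc1ccc(-c2ccc(-c3ccc(C(=N)N)c(F)c3)s2)cc1` has not yet been measured. It differs from compound 2 by methoxy in place of chloro on an aromatic carbon, the same change as from compound 3 to compound 1, made at the same kind of place. Because compound 3 to compound 1 gave a 1.7-fold higher number from compound 3 to compound 1 (0.24 log units; within the scatter), the step from compound 2 to compound 4 is expected to be of similar size, a 1.7-fold higher number from compound 2 to compound 4 (0.23 log units; within the scatter), in this assay . On that basis compound 4 is estimated at 380 nM, with a plausible span from 190 nM to 760 nM.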

Compound 4, concentration for 50% growth inhibition: 3160 nM
Beside the measured number, compound 4's estimate is 8.3-fold (0.92 log units) below it, and the stated range ends below it.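

The change from chloro to methoxy did not carry over from one core to the other in this assay. On the fluorinated core it gave a 14-fold higher number from compound 2 to compound 4 (1.15 log units; beyond the scatter), far more than on the core without fluoro: the same change on two cores in this assay, a 1.7-fold higher number (0.24 log units; within the scatter) from compound 3 to compound 1 and a 14-fold higher number (1.15 log units; beyond the scatter) from compound 2 to compound 4, 8.1-fold (0.91 log units) apart, beyond the scatter of two such steps. Seen from the other side, fluoro in place of hydrogen gave a 9.3-fold higher number from compound 1 to compound 4 (0.97 log units; beyond the scatter) when methoxy was present, so the effects of the two changes do not simply add up in this set: the same change on two cores in this assay, a 1.2-fold lower number (0.06 log units; within the scatter) from compound 2 to compound 3 and a 9.3-fold lower number (0.97 log units; beyond the scatter) from compound 4 to compound 1, 8.1-fold (0.91 log units) apart, beyond the scatter of two such steps. This shows that the result of one swap here depended on the other group in the molecule, but it rests on a single set of four compounds in one assay and does not show why the two groups behave this way together.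

As far as these compounds go, it remains open whether an ethoxy chain or an amine in place of the chloro on the fluorinated core would behave more like chloro or like methoxy. From the compounds shown here alone, it is also open whether a methyl group in place of the fluoro would give the same large step with methoxy present.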